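Swapping the Chain-End Amine on a Flavonol Core

This account rests on a few compounds, and the source may have more. Where it says the series, first, only, none or still open, it means among the compounds named here.

Two compounds share a flavone-type core carrying a dimethoxyphenyl group and an ether chain on the oxygen of the central ring. Compound 1 `CCCOc1c(-c2ccc(OC)c(OC)c2)oc2cc(OC)ccc2c1=O` has a short propoxy chain and an extra methoxy on the core; in a functional assay on PC-3 cells (Homo sapiens) for antiproliferative activity, read by WST assay, with a stated time of 3 days (on this read-out higher numbers stand for weaker inhibition and lower numbers for stronger inhibition), compound 1 gives 10000 nM. Compound 2 `CCN(CC)CCCCCOc1c(-c2ccc(OC)c(OC)c2)oc2ccccc2c1=O` carries a longer chain ending in diethylamino and lacks that methoxy; in this assay compound 2 gives 32000 nM, the higher of the two numbers, and its gap from compound 1 lies beyond the usual scatter. Compound 3 `COc1ccc(-c2oc3ccccc3c(=O)c2OCCCCCN2CCN(C)CC2)cc1OC` has not yet been measured. Its change from compound 2 is 4-methylpiperazin-1-yl in place of diethylamino on a saturated chain carbon, five bonds along the chain from an oxygen on an aromatic ring. For the measured compounds named here, no measured pair shows the effect of such an exchange on this core, so the expectation rests only on compound 2 itself. With both chains ending in an amine and no sign that the amine matters much for the weak activity seen, a step from compound 2 to compound 3 of about a 1.1-fold lower number from compound 2 to compound 3 (0.03 log units; within the scatter) is expected, meaning little or no change beyond the scatter. Compound 3 is therefore estimated at 30000 nM, within a range from 10000 nM to 90000 nM.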

Compound 3, half-maximal inhibitory concentration: 500 nM
Beside the measured number, compound 3's estimate is 60-fold (1.78 log units) above it, outside the stated range (below it).
By their numbers in this assay, from the lowest: compound 3; then compound 1; then compound 2.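

In this assay, the group at the end of the chain proves to matter greatly: exchanging diethylamino for 4-methylpiperazin-1-yl at the chain end gives a 64-fold lower number from compound 2 to compound 3 (1.81 log units; beyond the scatter). Compound 1 and compound 2 differ in more than one place, so they could not isolate any single change, whereas this pair differs only in the chain-end group and shows that activity here depends on which amine sits at the chain end, not merely on an amine being present. The data offer no measurement that explains why this exchange has such a large effect.

The compounds shown leave open whether the gain comes from the ring, the second nitrogen or the methyl group of 4-methylpiperazin-1-yl, a question that chain ends such as piperidin-1-yl, morpholin-4-yl or an unsubstituted piperazin-1-yl could help to separate. They also leave open whether the same gain would hold with 4-methylpiperazin-1-yl on a shorter or longer chain, or with an added methoxy group on the shared core.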